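The compounds below may be only part of what the source reports. "The series", "measured", "known", "first", "only" and "open" are said of these compounds alone.

The study concerns a small set of quinone-type compounds tested for cytotoxicity. Compound 3 `CC(=O)Oc1c(C)cc(Cl)c2c1C(=O)C=CC2=O` gives 28600 nM in a functional assay on SNO cells (Homo sapiens) for cytotoxicity, read by XTT assay, with a stated time of 24 h; a higher number here means a weaker inhibitor, a lower number a stronger inhibitor. For comparison, compound 1 `CCOc1cc(C)c(Cl)c2c1C(=O)C=CC2=O` gives 44200 nM in this assay, and compound 2 `CC(=O)Oc1cc(OC(C)=O)c2c(OC(C)=O)cc(C)c(Cl)c2c1OC(C)=O` gives 56900 nM. Compound 3 thus carries the lowest of the three numbers, yet its gaps to compound 1 and to compound 2 both lie within the usual scatter, so the three compounds cannot be separated on these data.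

Compound 4 `Cc1cc(Cl)c2c(c1O)C(=O)C=CC2=O` has not yet been measured in this assay. It differs from compound 3 in a single place: hydrogen in place of acetyl on an oxygen on an aromatic ring. For the measured compounds named here, no pair of measured compounds shows a change of this kind, so there is no precedent here for its size or direction. The author expects the step from compound 3 to compound 4 to be a 1.0-fold lower number from compound 3 to compound 4 (0.01 log units; within the scatter), that is, nothing beyond the scatter. The estimate for compound 4 in this assay is 28000 nM, with a range from 9000 nM to 90000 nM.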

Compound 4, half-maximal inhibitory concentration: 9400 nM
Estimate against measurement, compound 4: 3.0-fold (0.47 log units) above; low and high end bracket the measured number.
By their numbers in this assay, from the lowest: compound 4; then compounds 3, 1 and 2 (each within the scatter of the next).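

Exchanging acetoxy for hydroxy on an oxygen on an aromatic ring gives a 3.0-fold lower number from compound 3 to compound 4 (0.48 log units; beyond the scatter) in this assay. For the compounds shown here, this is the first step in the set that can be read beyond the scatter, and it shows that the group carried on this oxygen can shift the number, with the free hydroxy on the lower side. The step is modest and rests on this single pair, and nothing in the data bears on why the number moves.

On these data alone, whether a methoxy group, a longer ester such as butanoyl, or an amine in this place would read closer to compound 4 or to compound 3 remains open. As far as these compounds go, it is also open whether the same exchange would move the number in the same direction on another core.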